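Chloro in Place of Hydrogen: From Compound 2 to Compound 4

This account rests on a few compounds, and the source may have more. Where it says the series, first, only, none or still open, it means among the compounds named here.

Three compounds have been measured so far:
compound 1, `O=C(Nc1ccc(Cl)cc1Cl)c1ccc2cccnc2c1O`, 450 nM
compound 2, `O=C(Nc1cccc(C(F)(F)F)c1)c1cc(F)ccc1O`, 1800 nM
compound 3, `O=C(Nc1ccc(Cl)cc1)c1ccc2cccnc2c1O`, 380 nM

All three were tested in a functional assay on NALM-6 cells (Homo sapiens) for cytotoxicity, read by luminescence and CellTiter-Glo, with a stated time of 3 days; on this read-out lower numbers stand for stronger inhibition and higher numbers for weaker inhibition. Compound 1 and compound 3 share one core, and compound 2 has another; the difference between the two cores is not broken down here. In this assay compound 2 gives the highest of the three numbers, and the gaps to compound 1 and compound 3 lie beyond the scatter.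

One structural change appears twice among these compounds. From compound 3 to compound 1 it is chloro in place of hydrogen on an aromatic carbon, and the step it made was a 1.2-fold higher number from compound 3 to compound 1 (0.07 log units; within the scatter). From compound 2 to compound 4, whose structure is `O=C(Nc1ccc(Cl)c(C(F)(F)F)c1)c1cc(F)ccc1O`, it is chloro in place of hydrogen on an aromatic carbon. The surroundings differ: in compound 1 the chloro sits ortho to a large group and meta to a chloro group, whereas in compound 4 it sits ortho to a trifluoromethyl group and para to a large group, so this is the same kind of change rather than the same change.

Because the earlier step of a 1.2-fold higher number from compound 3 to compound 1 (0.07 log units; within the scatter) stayed within the scatter, compound 4 is expected to stay close to compound 2, with an estimated step of a 1.2-fold lower number from compound 2 to compound 4 (0.08 log units; within the scatter). Compound 4 is therefore estimated at 1500 nM, likely between 500 nM and 4500 nM.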

Compound 4, half-maximal inhibitory concentration: 970 nM
Compound 4: middle estimate off by 1.5-fold (0.19 log units), on the high side; the range from low to high includes it.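

In this assay chloro in place of hydrogen on an aromatic carbon makes a 1.9-fold lower number from compound 2 to compound 4 (0.27 log units; within the scatter) on the second core, and this step cannot be told apart from the earlier one: the same change on two cores in this assay, a 1.2-fold higher number (0.07 log units; within the scatter) from compound 3 to compound 1 and a 1.9-fold lower number (0.27 log units; within the scatter) from compound 2 to compound 4, 2.2-fold (0.34 log units) apart, within the scatter of two such steps. Within this series, then, the change carried over from the core of compound 1 to the core of compound 4 without the two steps parting beyond the scatter. Within the data shown here, this rests on only two pairs, with the chloro in different surroundings in each, so it shows no difference that these data can resolve and does not show that the change acts alike on both cores, let alone on any further core.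

The compounds shown leave open whether another group in the same place, such as a methoxy group, a nitrile or an amine, would carry over between the cores as chloro does. They also leave open how either core would respond to a change elsewhere, such as a carboxylic acid on the ring that bears the hydroxyl group.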